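Aryl ketone swap on the shared core: trimethoxy to chlorophenyl

The source may hold more compounds than are shown below. What is called first, only, known or untested is meant among the compounds shown, and "the series" means these compounds.

Measured compounds:
Compound 1, `COc1cc(-c2nnc3n2NC(c2cccs2)C(C(=O)c2ccccc2)S3)cc(OC)c1OC`: in a functional assay on HepG2 cells (Homo sapiens) for cytotoxicity, read by MTT assay, with a stated time of 48 h (on this read-out higher numbers stand for weaker inhibition and lower numbers for stronger inhibition), compound 1 gives > 100000 nM, which is a limit of the assay.
Compound 2, `COc1cc(C(=O)C2Sc3nnc(-c4cc(OC)c(OC)c(OC)c4)n3NC2c2cccs2)cc(OC)c1OC`: in this assay compound 2 gives > 100000 nM, likewise a limit of the assay.

For the measured compounds named here, compound 2 therefore stands only at a limit in this assay, and the one other value shown is also a limit; both sit at the limit of > 100000 nM in this assay, at which 2 of the 2 values shown sit. Going by the values given here, the single measured step, a step that the two limits leave unreadable from compound 1 to compound 2, cannot be read for size or direction.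

Compound 3, `COc1cc(-c2nnc3n2NC(c2cccs2)C(C(=O)c2ccc(Cl)cc2)S3)cc(OC)c1OC`, differs from compound 2 by 4-chlorophenyl in place of 3,4,5-trimethoxyphenyl on a carbonyl carbon. Among the compounds with values here, the only step that bears on a change at this carbonyl carbon is a step that the two limits leave unreadable from compound 1 to compound 2, which is unreadable, so no measured step gives a size or direction for the move to compound 3. With two limits and nothing else, the expectation for compound 3 is a further limit rather than a resolved number, and the step of a number no higher from compound 2 to compound 3 (the limit leaves the size open) is estimated as none beyond the scatter. Compound 3 is accordingly estimated at 100000 nM, with a range from 20000 nM to 500000 nM, most likely reported as a limit.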

Compound 3, half-maximal inhibitory concentration: 13200 nM
Beside the measured number, compound 3's estimate is 7.6-fold (0.88 log units) above it; measured number below the stated range.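

In this assay, for the compounds shown here, 4-chlorophenyl in place of 3,4,5-trimethoxyphenyl on a carbonyl carbon gives an at least 7.5-fold lower number from compound 2 to compound 3 (0.87 log units; beyond the scatter), the first readable change at this place on the shared core. Chloro in place of hydrogen on an aromatic carbon gives an at least 7.5-fold lower number from compound 1 to compound 3 (0.87 log units; beyond the scatter), so this single change to the phenyl group of compound 1 is enough to leave the limit. Compound 3 is thus the only compound shown with a resolved number in this assay, while the other two values remain limits: the limit of > 100000 nM in this assay, at which 2 of the 3 values shown sit.

On these data alone, the step from compound 1 to compound 2 cannot be read, and the two readable steps fix only a lower bound, so the true size of the change and any order between phenyl and 3,4,5-trimethoxyphenyl stay open. Also open, as far as these compounds go, is how a 4-fluorophenyl, a 4-methylphenyl or a 4-aminophenyl on this carbonyl carbon would read in this assay, and so whether the change seen here is specific to chloro.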